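Swapping Heptyl for Bromophenyl: Effect on Cell Inhibition

The source may report more compounds than this note shows. Statements on the series, on what has been measured and on what is new or still open speak of the compounds shown alone.

Measured compounds:
Compound 1, `CCCCCCCCn1cc(/C=C/C(=O)c2ccc(N)cc2)nn1`, gives 26900 nM in a functional assay on HeLa cells (Homo sapiens) for inhibition, read by MTT assay; a lower number here means a stronger inhibitor, a higher number a weaker inhibitor.
Compound 2, `CCCCCCCCn1cc(/C=C/C(=O)c2ccc(NC(=O)CN3CCN(C(=O)OC(C)(C)C)CC3)cc2)nn1`, gives 32100 nM in this assay.
Compound 3, `CC(C)(C)OC(=O)N1CCN(CC(=O)Nc2ccc(C(=O)/C=C/c3cn(Cc4ccc(Br)cc4)nn3)cc2)CC1`, gives 18900 nM in this assay.

Compound 4, `Nc1ccc(C(=O)/C=C/c2cn(Cc3ccc(Br)cc3)nn2)cc1`, has not yet been measured. It arises from compound 1 by the change (4-bromophenyl in place of heptyl on a saturated chain carbon bound to an aromatic nitrogen). The same change carries compound 2 to compound 3, where it made a step of a 1.7-fold lower number from compound 2 to compound 3 (0.23 log units; within the scatter). How the core of compound 1 differs from that of compound 2 is not broken down here. All three measured values lie within the scatter of one another, so no order among them can be read. A step of similar size is expected a 1.5-fold lower number from compound 1 to compound 4 (0.17 log units; within the scatter), because the earlier step of a 1.7-fold lower number from compound 2 to compound 3 (0.23 log units; within the scatter) was also small. Compound 4 is therefore estimated at 18000 nM in this assay, with a likely range from 7000 nM to 45000 nM.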

Compound 4, half-maximal inhibitory concentration: 16400 nM
Compound 4: middle estimate off by 1.1-fold (0.04 log units), on the high side; measured number inside the range.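

Carrying the change from heptyl to 4-bromophenyl onto the core of compound 1 gives, in this assay, a 1.6-fold lower number from compound 1 to compound 4 (0.21 log units; within the scatter). As far as these numbers go, the change behaves alike on both cores: the same change on two cores in this assay, a 1.7-fold lower number (0.23 log units; within the scatter) from compound 2 to compound 3 and a 1.6-fold lower number (0.21 log units; within the scatter) from compound 1 to compound 4, 1.0-fold (0.02 log units) apart, within the scatter of two such steps. Both steps are within the scatter, however, so this is agreement between two small steps and does not show that the change really shifts the number on either core.

The compounds shown leave open whether a different group in the same place, such as a plain benzyl, a shorter chain or a chain ending in a carboxylic acid, would give a step beyond the scatter. They also leave open whether a larger step would carry from one core to the other as closely as these small ones do.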